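A few compounds are considered here, and "the series" means these few. Any claim that something is new, unique, unknown or untested is made for them only; others in the source may bear on it.

In an ADME assay on microsomes from liver (Homo sapiens) for metabolic stability, read by LC-MS, with a stated time of 10 min (on this read-out higher numbers stand for a more stable compound and lower numbers for a less stable compound), compound 1 `CN(C[C@H]1Cc2c(cccc2N2CCN(C3COC3)CC2)CN1)[C@H]1CCCc2cccnc21` gives 83.1% and sits within the scatter of compound 3 `CC(C)N(C[C@H]1Cc2c(cccc2N2CCNCC2)CN1)[C@H]1CCCc2cccnc21` at 75% while compound 2 `CN(C[C@H]1Cc2c(cccc2N2CCNC(C)(C)C2)CN1)[C@H]1CCCc2cccnc21` reaches 100% on the same scale. Compound 4 `CN(C[C@H]1Cc2c(cccc2N2CCN(c3ncccn3)CC2)CN1)[C@H]1CCCc2cccnc21` has pyrimidin-2-yl in place of oxetan-3-yl on an amine nitrogen in a ring and keeps the rest of compound 1. Among the measured compounds shown here, the one measured step that removes oxetan-3-yl is a number 16.9 percentage points higher from compound 1 to compound 2 (beyond the scatter) and that step is modest. For the measured compounds named here, it brings in no aromatic ring, and no measured compound carries one at this nitrogen, so it guides only the size. The estimated step is a number 8.1 percentage points lower from compound 1 to compound 4 (within the scatter) in this assay as a small fall, not expected beyond the scatter. For compound 4 the expected value is 75% with an estimated range of 55% to 92% around it.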

Compound 4, percent of the compound remaining: 35.5%
The estimate for compound 4 lay 39.5 percentage points above the measured number, and the stated range ends above it.
By their numbers in this assay, from the lowest: compound 4; then compounds 3 and 1 (each within the scatter of the next); then compound 2.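

In this assay the group on the amine nitrogen in a ring clearly matters: pyrimidin-2-yl in place of oxetan-3-yl gives a number 47.6 percentage points lower from compound 1 to compound 4 (beyond the scatter) and this step is large. Among the compounds shown here, this position therefore does not tolerate every group equally, although this single pair is the only reading of an aromatic ring there. Nothing available explains the step.

For the compounds shown here, it remains open whether the step follows any aromatic ring on this nitrogen or only this ring with its 2 hetero atoms. A phenyl or pyridin-2-yl group there would tell these apart.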